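Swapping fluoro for chloro on the aryl ring

This account rests on a few compounds, and the source may have more. Where it says the series, first, only, none or still open, it means among the compounds named here.

Compound 1 `CC1(C)[C@H]2CC[C@]1(C)N(Cc1cn(-c3ccc(C#N)cc3)nn1)C(=O)C2` measured at 11300 nM
Compound 2 `CC1(C)[C@H]2CC[C@]1(C)N(Cc1cn(-c3ccccc3F)nn1)C(=O)C2` measured at 5160 nM

Within the data shown here, in an ADME assay on GES1 cells (Homo sapiens) for cytotoxicity, read by MTT assay, with a stated time of 24 h (a lower number here means that less compound is tolerated, a higher number that more compound is tolerated), only two numbers exist so far, and compound 2 holds the lower one at 5160 nM while compound 1 holds the higher. The nearest neighbour of compound 2 is therefore compound 1, and the gap between them is beyond the usual scatter of repeat measurements.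

Compound 3 `CC1(C)[C@H]2CC[C@]1(C)N(Cc1cn(-c3ccccc3Cl)nn1)C(=O)C2` has not been measured yet. It differs from compound 2 in one place only: chloro in place of fluoro on an aromatic carbon with chloro in place of fluoro on an aromatic carbon, ortho to a large group.

Just one measured step bears on this, and only loosely. It is a 2.2-fold lower number from compound 1 to compound 2 (0.34 log units; beyond the scatter) and it is modest, even though it replaces 4-cyanophenyl with 2-fluorophenyl. Among the measured compounds shown here, no measured pair swaps fluoro for chloro, so the direction of the new step is unknown, and a change smaller than that modest one seems the reasonable expectation.

The expected step is a 1.1-fold higher number from compound 2 to compound 3 (0.03 log units; within the scatter) and this is only an estimate. Compound 3 is expected near 5500 nM with 2600 nM to 11500 nM as the estimated range.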

Compound 3, half-maximal cytotoxic concentration: 5370 nM
Beside the measured number, compound 3's estimate is 1.0-fold (0.01 log units) above it; the range from low to high includes it.
By their numbers in this assay, from the lowest: compounds 2 and 3 (each within the scatter of the next); then compound 1.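

In this assay, chloro in place of fluoro on an aromatic carbon, ortho to a large group, gives a 1.0-fold higher number from compound 2 to compound 3 (0.02 log units; within the scatter) and so leaves the two compounds indistinguishable, which means this assay does not tell these two groups apart at this position. The 2-chlorophenyl group also behaves like the 2-fluorophenyl group when each is set against the 4-cyanophenyl group: the step of a 2.1-fold lower number from compound 1 to compound 3 (0.32 log units; beyond the scatter) points the same way as the earlier step of a 2.2-fold lower number from compound 1 to compound 2 (0.34 log units; beyond the scatter) and is likewise modest. Nothing shown here explains either result.

The comparison with compound 1 changes both the group and where it sits on the phenyl ring, so the compounds shown cannot say which of the two matters for the modest step. As far as these compounds go, it also remains open whether a group of a different kind on that same aromatic carbon, such as methoxy or an amine, would stay with compounds 2 and 3 in this assay or move away from them.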